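A few compounds are considered here, and "the series" means these few. Any claim that something is new, unique, unknown or untested is made for them only; others in the source may bear on it.

The series shares one core, seen unadorned in compound 3 `COc1cc(-c2nnc(SCc3ccccc3)o2)ccc1O`, where in a functional assay on cells (T-cell, Mus musculus, strain BALB/c) for inhibition, read by MTT assay, with stated times of 24 h and 72 h (on this read-out lower numbers stand for stronger inhibition and higher numbers for weaker inhibition), compound 3 gives 1250 nM. Compound 1 `COc1cc(-c2nnc(SCc3ccccc3[N+](=O)[O-])o2)ccc1O` carries a nitro group on the benzyl ring, and in this assay compound 1 gives 9600 nM; compound 2 `COc1cc(-c2nnc(SCc3ccccc3Br)o2)ccc1O` carries bromo in the same place, and in this assay compound 2 gives 17800 nM. Compound 2 thus stands at the highest of the three numbers. Its nearest neighbour is compound 1, with a 1.9-fold higher number from compound 1 to compound 2 (0.27 log units; within the scatter), while compound 3 lies furthest, with a 14-fold lower number from compound 2 to compound 3 (1.15 log units; beyond the scatter) and, from the nitro analogue, a 7.7-fold lower number from compound 1 to compound 3 (0.89 log units; beyond the scatter). Compound 4 `COc1cc(-c2nnc(SCc3ccccc3Br)o2)ccc1OCc1ccccc1Br` differs from compound 2 in a single place: 2-bromobenzyl in place of hydrogen on an oxygen on an aromatic ring. For the measured compounds named here, no measured step touches that oxygen; the three steps speak only of groups on the benzyl ring, where each group present went with a higher number than in compound 3. The data therefore give no firm direction for this change, and a step near the scatter, leaning upward, is expected, estimated as a 1.7-fold higher number from compound 2 to compound 4 (0.23 log units; within the scatter). On that basis compound 4 is expected to give 30000 nM, with a range from 6000 nM to 150000 nM.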

Compound 4, half-maximal inhibitory concentration: 8710 nM
Estimate against measurement, compound 4: 3.4-fold (0.54 log units) above; the range from low to high includes it.
By their numbers in this assay, from the lowest: compound 3; then compounds 4, 1 and 2 (each within the scatter of the next, the first and the last beyond it).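

In this assay, the oxygen on the aromatic ring tolerates substitution: 2-bromobenzyl in place of hydrogen there gives a 2.0-fold lower number from compound 2 to compound 4 (0.31 log units; beyond the scatter). For the compounds shown here, the earlier steps spoke only of groups on the benzyl ring, so this is the first reading at this oxygen, and it shows that, with bromo on the benzyl ring, the free hydroxy is not needed to keep the number in this range. The step also runs downward, whereas compounds 1 and 2, with their added groups on the benzyl ring, stood higher than compound 3; nothing available explains this result.

Going by these compounds, whether the whole 2-bromobenzyl group matters, or a simple methyl or unsubstituted benzyl on that oxygen would do the same, stays open. So does the outcome with a carboxylic acid or an amine-bearing chain there.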